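Working notes: three measured analogues and one pending

The source may report more compounds than this note shows. Statements on the series, on what has been measured and on what is new or still open speak of the compounds shown alone.

Measured so far in a functional assay on BV-173 cells (Homo sapiens) for cytotoxicity, read by MTT assay, with a stated time of 72 h; on this read-out lower numbers stand for stronger inhibition and higher numbers for weaker inhibition:
- compound 1, `O=C(/C=C/c1ccccc1)c1ccc2[nH]c(=O)oc2c1`: 18400 nM
- compound 2, `CN(C)Cn1c(=O)oc2cc(C(=O)/C=C/c3ccccc3)ccc21`: 6600 nM
- compound 3, `COc1ccccc1N1CCN(Cn2c(=O)oc3cc(C(=O)/C=C/c4ccccc4)ccc32)CC1`: 9200 nM

Compound 3 gives the second highest of the three numbers. Its nearest neighbour is compound 2, and the two values lie within the scatter of each other, so nothing can be said about their order. The furthest is compound 1, and that gap too stays within the scatter. Going by the values given here, the only step beyond the scatter in this set is a 2.8-fold lower number from compound 1 to compound 2 (0.45 log units; beyond the scatter).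

Compound 4, `O=C(/C=C/c1ccccc1)c1ccc2c(c1)oc(=O)n2CN1CCN(Cc2ccccc2)CC1`, is the next compound to be measured in this assay. It differs from compound 3 in one place: benzyl in place of 2-methoxyphenyl on an amine nitrogen in a ring. Among the compounds with values here, no measured pair bears on this change directly. Within the data shown here, the single step beyond the scatter, from compound 1 to compound 2, concerns a substituent on the aromatic nitrogen and not the amine nitrogen in the ring where the new group enters, so it gives no guidance here. The values of compound 2 and compound 3 show that a change of the group on the ring amine nitrogen has, so far, not moved the number beyond the scatter.

On this basis the step is expected to be a 1.0-fold lower number from compound 3 to compound 4 (0.01 log units; within the scatter), that is, none beyond the scatter. Compound 4 is therefore estimated at 9000 nM, with a range from 4000 nM to 20000 nM.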

Compound 4, half-maximal inhibitory concentration: 9400 nM
Estimate against measurement, compound 4: 1.0-fold (0.02 log units) below; the measured number falls inside the stated range.
By their numbers in this assay, from the lowest: compounds 2, 3, 4 and 1 (each within the scatter of the next, the first and the last beyond it).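

In this assay, going by these compounds alone, the exchange of 2-methoxyphenyl for benzyl on the amine nitrogen in the ring gives a 1.0-fold higher number from compound 3 to compound 4 (0.01 log units; within the scatter) and is the first direct comparison of two groups at this position. The pair shows that this position tolerates the change without a shift beyond the scatter, even though the hydrogen-bond acceptor of 2-methoxyphenyl is absent from benzyl and the aromatic ring of carbon only is present in both groups, so neither that acceptor nor the difference between these two groups separates compound 3 from compound 4 in this assay. No measurement is at hand that explains this result.

As far as these compounds go, all that has been compared at this position is two groups that each carry a six-membered aromatic ring of carbon only, so it remains open whether a group without such a ring, such as a plain methyl, an acetyl or a chain ending in a carboxylic acid, would also leave the number within the scatter. Also open, from the compounds shown here alone, is whether a substituent such as chlorine or a methoxy group on the ring of the benzyl would move the number beyond the scatter.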